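A few compounds are considered here, and "the series" means these few. Any claim that something is new, unique, unknown or untested is made for them only; others in the source may bear on it.

Measured compounds:

Compound 1, `CN(C(=O)NC(=O)c1ccc(F)c(F)c1)c1nc(C(F)(F)F)c(C(=O)N/N=C/c2ccc(C(F)(F)F)cc2)s1`: in a functional assay on BCG823 cells (Homo sapiens) for inhibition, read by MTT assay, with a stated time of 72 h (on this read-out lower numbers stand for stronger inhibition and higher numbers for weaker inhibition), compound 1 gives 3.85 ug/mL.
Compound 2, `CN(C(=O)NC(=O)c1ccc(F)c(F)c1)c1nc(C(F)(F)F)c(C(=O)N/N=C/c2ccccc2C(F)(F)F)s1`: in this assay compound 2 gives 3.66 ug/mL.
Compound 3, `CN(C(=O)NC(=O)c1c(F)cccc1F)c1nc(C(F)(F)F)c(C(=O)N/N=C/c2ccc(C(F)(F)F)cc2)s1`: in this assay compound 3 gives 34.9 ug/mL.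

Compound 4, `CN(C(=O)NC(=O)c1c(F)cccc1F)c1nc(C(F)(F)F)c(C(=O)N/N=C/c2ccccc2C(F)(F)F)s1`, has not yet been measured in this assay. It differs from compound 3 in one place: 2-(trifluoromethyl)phenyl in place of 4-(trifluoromethyl)phenyl on a carbon with a double bond to nitrogen. The same change has already been made once among the measured compounds, from compound 1 to compound 2, where the difference is 2-(trifluoromethyl)phenyl in place of 4-(trifluoromethyl)phenyl on a carbon with a double bond to nitrogen, and it made a step of a 1.1-fold lower number from compound 1 to compound 2 (0.02 log units; within the scatter). The place of the change reads the same in both pairs, so the change is the same one.

The two cores differ elsewhere: 2,6-difluorophenyl in place of 3,4-difluorophenyl on a carbonyl carbon, and this difference is tied to a step of a 9.1-fold higher number from compound 1 to compound 3 (0.96 log units; beyond the scatter), which sets compound 3 apart from compound 1 and compound 2.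

For compound 4 the expectation rests on the one earlier occurrence of the same change. Because the step of a 1.1-fold lower number from compound 1 to compound 2 (0.02 log units; within the scatter) lay within the scatter, the estimated step from compound 3 to compound 4 is also expected to be small, a 1.1-fold lower number from compound 3 to compound 4 (0.04 log units; within the scatter). Compound 4 is therefore expected to give about 32 ug/mL in this assay, with a range estimated from 15 ug/mL to 70 ug/mL. This rests on a single prior instance of the change, so the expectation is held loosely.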

Compound 4, half-maximal inhibitory concentration: 17 ug/mL
Compound 4: middle estimate off by 1.9-fold (0.27 log units), on the high side; the range from low to high includes it.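

In this assay, 2-(trifluoromethyl)phenyl in place of 4-(trifluoromethyl)phenyl gives a 2.1-fold lower number from compound 3 to compound 4 (0.31 log units; beyond the scatter) on the core bearing 2,6-difluorophenyl, and although only this step lies beyond the scatter, it does not differ measurably from the earlier step on the core bearing 3,4-difluorophenyl: the same change on two cores in this assay, a 1.1-fold lower number (0.02 log units; within the scatter) from compound 1 to compound 2 and a 2.1-fold lower number (0.31 log units; beyond the scatter) from compound 3 to compound 4, 2.0-fold (0.29 log units) apart, within the scatter of two such steps

The difluorophenyl change also carries across, with a 4.6-fold higher number from compound 2 to compound 4 (0.67 log units; beyond the scatter) on the core bearing 2-(trifluoromethyl)phenyl, a step in the same direction as a 9.1-fold higher number from compound 1 to compound 3 (0.96 log units; beyond the scatter) and not measurably different from it: the same change on two cores in this assay, a 9.1-fold higher number (0.96 log units; beyond the scatter) from compound 1 to compound 3 and a 4.6-fold higher number (0.67 log units; beyond the scatter) from compound 2 to compound 4, 2.0-fold (0.29 log units) apart, within the scatter of two such steps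

Within these four compounds, then, the two changes behave much the same on either core, but this is one square of compounds, so it shows neither that the steps are independent of the core in general nor that the size of either step would hold for other members of the series.

The compounds shown leave open what a methoxy group, a nitrile or an amine would give in place of the trifluoromethyl group on the phenyl ring. They also leave open what an unsubstituted phenyl or a chlorophenyl would give on the carbonyl carbon in place of the difluorophenyl groups.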